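Permeability of a Hydroxyalkyl Swap on Two Related Cores

The compounds below may be only part of what the source reports. "The series", "measured", "known", "first", "only" and "open" are said of these compounds alone.

Compound 1 `COc1ccc(Cn2c(-c3ccccc3)c(-c3ccccc3)c3c(=N)n([C@H]4CC[C@H](O)CC4)cnc32)cc1`: > 1000 10^-6 cm/s
Compound 2 `COc1ccc(Cn2c(-c3ccccc3)c(-c3ccccc3)c3c(=N)n(CCO)cnc32)cc1`: > 1000 10^-6 cm/s
Compound 3 `COc1ccc(-c2c(-c3ccc(OC)cc3)n(Cc3ccccc3)c3ncn([C@H]4CC[C@H](O)CC4)c(=N)c23)cc1`: 196 10^-6 cm/s

In an ADME assay for permeability, using PAMPA, with a stated time of 30 min, at pH 7.4 (a higher number here means that the compound crosses the layer faster, a lower number that the compound crosses the layer more slowly), compound 1 gives > 1000 10^-6 cm/s, which is a limit of the assay and not a number. Compound 2 gives > 1000 10^-6 cm/s, also a limit. The step that the two limits leave unreadable from compound 1 to compound 2, made by 2-hydroxyethyl in place of 4-hydroxycyclohexyl on an aromatic nitrogen, therefore cannot be sized. Among the measured compounds shown here, compound 3 gives 196 10^-6 cm/s in this assay, the only number among the three; how its core differs from that of compound 1 is not broken down here. The unmeasured compound 4 `COc1ccc(-c2c(-c3ccc(OC)cc3)n(Cc3ccccc3)c3ncn(CCO)c(=N)c23)cc1` differs from compound 3 by 2-hydroxyethyl in place of 4-hydroxycyclohexyl on an aromatic nitrogen, the same change as from compound 1 to compound 2, with the surroundings of the place described in identical words. For the measured compounds named here, the only evidence on the measured step is the limit of > 1000 10^-6 cm/s in this assay, at which 2 of the 3 values shown sit, which gives no direction. Compound 4 is therefore expected to stay near compound 3, with a 1.1-fold higher number from compound 3 to compound 4 (0.05 log units; within the scatter) estimated as small. Compound 4 is estimated at 220 10^-6 cm/s, between 100 10^-6 cm/s and 480 10^-6 cm/s.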

Compound 4, apparent permeability: > 1000 10^-6 cm/s
Compound 4 was reported as a limit (the forecaster's own chance of this, stated with the estimate: 8%); middle value at least 4.5-fold (0.65 log units) from the limit.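

In this assay, 2-hydroxyethyl in place of 4-hydroxycyclohexyl on an aromatic nitrogen gives an at least 5.1-fold higher number from compound 3 to compound 4 (0.70 log units; beyond the scatter), so on the core of compound 3 the change raises the number beyond the scatter. The step from compound 1 to compound 2 cannot be read, so the result neither confirms nor refutes that the change carries from one core to the other, and on the core of compound 3 it has only a lower bound for its size. What restricts the reading is this: the limit of > 1000 10^-6 cm/s in this assay, at which 3 of the 4 values shown sit.

The compounds shown leave open how the number would respond on either core to a longer hydroxyalkyl chain, an amine or a carboxylic acid on the same nitrogen. They also leave open the full size of the step on either core.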